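This account rests on a few compounds, and the source may have more. Where it says the series, first, only, none or still open, it means among the compounds named here.

Compound 1, `CC(C)(C)OC(=O)N1CCC(O[C@H]2CC[C@H](Oc3ccc(C#N)cc3)CC2)CC1`: 45 nM
Compound 2, `CC(C)(C)OC(=O)N1CCC(O[C@H]2CC[C@H](Oc3cnc(S(C)(=O)=O)cn3)CC2)CC1`: 64 nM
Compound 3, `CC(C)S(=O)(=O)c1cnc(O[C@H]2CC[C@H](OC3CCN(C(=O)OC(C)(C)C)CC3)CC2)cn1`: 54 nM

Of the compounds shown here, three built on the shared core have been measured in a functional assay on isolated protein for agonist activity at Glucose-dependent insulinotropic receptor (Rattus norvegicus), read by HTRF and cAMP accumulation; a higher number here means that more compound is needed for the effect, a lower number that less compound is needed. Compound 1 gives 45 nM, compound 2 gives 64 nM and compound 3 gives 54 nM. Compound 2 carries the largest of the three numbers, but the gap to its nearest neighbour, a 1.2-fold lower number from compound 2 to compound 3 (0.07 log units; within the scatter), and the gap to its furthest, a 1.4-fold higher number from compound 1 to compound 2 (0.15 log units; within the scatter), both lie within the scatter, so the three compounds cannot be told apart on these numbers.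

Compound 4 `CS(=O)(=O)c1cnc(O[C@H]2CC[C@H](OC3CCN(C(=O)Oc4ccccc4)CC3)CC2)cn1` differs from compound 2 by phenyl in place of tert-butyl on an oxygen next to a carbonyl group. Neither measured step touches this end of the molecule: the change from compound 1 to compound 2 sits on the oxygen on a saturated carbon, and the change from compound 2 to compound 3 sits on the sulfonyl sulfur. Both were within the scatter, and nothing measured bears directly on the carbamate. In this assay, therefore, the step from compound 2 to compound 4 is expected to be no change at the digits printed from compound 2 to compound 4 (within the scatter), with no direction beyond the scatter supported by the data. Compound 4 is accordingly estimated at 64 nM, with a range from 20 nM to 250 nM.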

Compound 4, half-maximal effective concentration: 71.8 nM
Compound 4: the middle estimate sits 1.1-fold (0.05 log units) below what was measured; the measured number falls inside the stated range.
By their numbers in this assay, from the lowest: compounds 1, 3, 2 and 4 (each within the scatter of the next).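

In this assay, among the compounds shown here, phenyl in place of tert-butyl on an oxygen next to a carbonyl group gives a 1.1-fold higher number from compound 2 to compound 4 (0.05 log units; within the scatter), the first reading at this position, since the earlier steps changed other places on the shared core. Within these two compounds, then, a group with one six-membered aromatic ring of carbon only takes the place of a group with no ring, and the number stays within the scatter. Nothing at hand accounts for this result at the level of the molecule.

From the compounds shown here alone, with only tert-butyl and phenyl seen here, it remains open whether a benzyl group, an ethyl group or a phenyl ring bearing a fluorine would also stay within the scatter. Going by these compounds, it is equally open whether phenyl would read the same alongside the 4-cyanophenyl of compound 1 or the isopropyl group of compound 3.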